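Configuration at the chain stereocentre: compound 2 to compound 3

The source may report more compounds than this note shows. Statements on the series, on what has been measured and on what is new or still open speak of the compounds shown alone.

Measured so far in a physicochemical assay for lipophilicity, at pH 7.4; a lower number here means a more polar compound, a higher number a more lipophilic compound:
- Compound 1 `Cc1cc(C)c(CN2CCc3c(Cl)cc(-c4c(C)noc4C)c(Cl)c3C2=O)c(=O)[nH]1`: 3.1
- Compound 2 `Cc1cc(C)c(CN2CCc3c(Cl)cc([C@H](C)CO)c(Cl)c3C2=O)c(=O)[nH]1`: 2.6

Compound 2 holds the lower of the two numbers at 2.6, and the gap to compound 1 lies beyond the scatter. The next compound to be measured is compound 3 `Cc1cc(C)c(CN2CCc3c(Cl)cc([C@@H](C)CO)c(Cl)c3C2=O)c(=O)[nH]1`. The structural change is the two compounds have the same atoms and bonds and differ only in configuration as drawn: 1 of 1 stereo elements differ; a stereocentre at a saturated chain carbon is drawn S in compound 2 and R in compound 3. For the measured compounds named here, only one measured step is available, a number 0.50 log units lower from compound 1 to compound 2 (beyond the scatter). That step exchanges one group for another on an aromatic carbon, so it bears on this comparison only indirectly and gives no size for a change of configuration. Going by the values given here, no measured pair differs in configuration alone, so the data offer no direct precedent. With the same atoms and bonds in both compounds, no step beyond the scatter is expected in this assay, and no direction is favoured. The expected step is no change at the digits printed from compound 2 to compound 3 (within the scatter). The estimate rests on compound 2 and its value of 2.6. For compound 3 the expected value is 2.6, with an estimated range from 2.3 to 2.9.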

Compound 3, distribution coefficient: 2.5
Estimate against measurement, compound 3: 0.10 log units above; measured number inside the range.
By their numbers in this assay, from the lowest: compounds 3 and 2 (each within the scatter of the next); then compound 1.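

In this assay, the stereocentre on the 1-(hydroxymethyl)ethyl chain now has its first direct reading, with a step of a number 0.10 log units lower from compound 2 to compound 3 (within the scatter). This comparison isolates the configuration at the saturated chain carbon, drawn S in compound 2 and R in compound 3, because nothing else separates the pair: the fact that compounds 2 and 3 differ only in the configuration as drawn. For the compounds shown here, the exchange of 3,5-dimethyl-1,2-oxazol-4-yl for 1-(hydroxymethyl)ethyl on the aromatic carbon, earlier seen only with the S form, now also has a reading with the R form, a number 0.60 log units lower from compound 1 to compound 3 (beyond the scatter), so in this assay that exchange stays beyond the scatter with either configuration drawn.

On these data alone, whether the two configurations also stay within the scatter of each other on other chains remains open, for instance with an amine or a carboxylic acid in place of the hydroxyl, or with a longer chain at the same stereocentre. The compounds shown carry this single read-out, so how the S and R forms compare in any other kind of assay also stays open.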